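The compounds below may be only part of what the source reports. "The series", "measured", "known", "first", "only" and "open" are said of these compounds alone.

Measured so far, in an ADME assay on L02 cells (Homo sapiens) for cytotoxicity, read by MTT assay, with a stated time of 72 h; on this read-out lower numbers stand for stronger inhibition and higher numbers for weaker inhibition:
Compound 1 `Cn1nc(-c2nnc(-c3ccccc3)o2)c2ccccc21` gives 84600 nM.
Compound 2 `Cc1ccc(-c2nnc(-c3nn(C)c4ccccc34)o2)cc1` gives only a limit of the assay, > 100000 nM.

Compound 2 therefore stands at the limit of > 100000 nM in this assay, at which 1 of the 2 values shown sits, and not at a number. For the measured compounds named here, the one measured step, an at least 1.1-fold higher number from compound 1 to compound 2 (0.07 log units; that floor lies within the scatter), lies within the scatter. Compound 3 `Cn1nc(-c2nnc(-c3ccc(Br)cc3)o2)c2ccccc21` differs from compound 2 by bromo in place of methyl on an aromatic carbon. Going by the values given here, no measured step exchanges a methyl for a bromo, so nothing here points to a shift beyond the scatter in this assay. Compound 3 is expected to stay near the limit, at an estimated 100000 nM, within 50000 nM to 200000 nM. The expected step is a number no higher from compound 2 to compound 3 (the limit leaves the size open).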

Compound 3, half-maximal inhibitory concentration: > 100000 nM
Compound 3 gave a limit, no number; the forecaster's own chance of this, stated with the estimate: 50%; the middle value sits exactly at the limit.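

A bromo on this aromatic carbon behaves like methyl in that the reading again reaches the edge of what this assay can report: the limit of > 100000 nM in this assay, at which 2 of the 3 values shown sit. Bromo in place of hydrogen gives an at least 1.1-fold higher number from compound 1 to compound 3 (0.07 log units; that floor lies within the scatter), so the data show no shift beyond the scatter, although the true size stays unknown. The step from methyl to bromo cannot be read, as both ends are limits.

Still open, from the compounds shown here alone, is how far the true values of compound 2 and compound 3 lie past the limit. Going by these compounds, whether an amine or a carboxylic acid on this carbon would give a readable number is also open.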